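Piperidinyl for dimethylamino: one step across two cores

The source may report more compounds than this note shows. Statements on the series, on what has been measured and on what is new or still open speak of the compounds shown alone.

Compound 1 `COc1ccc(/C(C)=C/CN(C)C)cc1` carries a dimethylamino group on the chain; in an assay on cell membranes for displacement of a labelled ligand from Sigma non-opioid intracellular receptor 1 (Cavia porcellus), read by scintillation counting, with a stated time of 150 min (on this read-out lower numbers stand for stronger inhibition and higher numbers for weaker inhibition), compound 1 gives 806 nM. Compound 2 `COc1ccc(/C(C)=C/CN2CCCCC2)cc1` differs from it only by piperidin-1-yl in place of dimethylamino on a saturated chain carbon bound to a double-bonded chain carbon; in this assay compound 2 gives 14 nM. That change produces a 58-fold lower number from compound 1 to compound 2 (1.76 log units; beyond the scatter). Compound 3 `COc1cccc(/C(C)=C/CN(C)C)c1` has the same atoms as compound 1 joined differently, and how the two cores differ is not broken down here. In this assay compound 3 reaches only the limit of the measurement, > 1000 nM. Compound 4 `COc1cccc(/C(C)=C/CN2CCCCC2)c1` is not yet measured; it stands to compound 3 as compound 2 stands to compound 1, by piperidin-1-yl in place of dimethylamino on a saturated chain carbon bound to a double-bonded chain carbon, the same change at the same place. The step expected for compound 4 is an at least 8.3-fold lower number from compound 3 to compound 4 (0.92 log units; beyond the scatter), resting on a 58-fold lower number from compound 1 to compound 2 (1.76 log units; beyond the scatter). The starting point is uncertain because compound 3 sits at the limit of > 1000 nM in this assay, at which 1 of the 3 values shown sits, so the expectation for compound 4 is broad. Compound 4 is expected to give about 120 nM in this assay, estimated between 30 nM and 700 nM.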

Compound 4, inhibition constant: 91 nM
Estimate against measurement, compound 4: 1.3-fold (0.12 log units) above; the range from low to high includes it.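

In this assay the change to piperidin-1-yl in place of dimethylamino carries over to the second core, with an at least 10-fold lower number from compound 3 to compound 4 (1.04 log units; beyond the scatter), so the number falls in the same direction on both cores shown. This does not show that the step has the same size on the two cores: the same change on two cores in this assay, a 58-fold lower number (1.76 log units; beyond the scatter) from compound 1 to compound 2 and an at least 10-fold lower number (1.04 log units; beyond the scatter) from compound 3 to compound 4; the limit leaves it open whether they differ. Compound 3 stands only at a limit of the assay, so the new step gives a minimum size and not a measured one: the limit of > 1000 nM in this assay, at which 1 of the 4 values shown sits.

The compounds shown leave open whether other cyclic amines, such as pyrrolidin-1-yl or morpholin-4-yl, would follow piperidin-1-yl on these cores, and whether a longer chain carrying the piperidin-1-yl would keep the step. As far as these compounds go, the transfer also rests on just these two cores, so it remains open whether it would hold with a hydroxy group in place of the methoxy group.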